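Pentyl for Isopropyl on the Sulfonylurea Nitrogen

The source may hold more compounds than are shown below. What is called first, only, known or untested is meant among the compounds shown, and "the series" means these compounds.

Compound 2 `CC(C)NC(=O)NS(=O)(=O)c1cc(C#N)ccc1Nc1ccc(F)cc1` stands level with compound 1 `CCCCCNC(=O)NS(=O)(=O)c1cc(C#N)ccc1Nc1ccccc1C`: in a functional assay on HEK293 cells for antagonist activity at thromboxane A2 receptor (Homo sapiens), read by fluorescence and calcium flux (on this read-out lower numbers stand for stronger inhibition and higher numbers for weaker inhibition), compound 2 gives 7830 nM, and compound 1 gives 7850 nM, the two numbers lying within the scatter of each other. Compound 3 `CCCCCNC(=O)NS(=O)(=O)c1cc(C#N)ccc1Nc1ccc(F)cc1` carries pentyl in place of isopropyl on an amide-type nitrogen. For the measured compounds named here, no measured pair shows this change on its own; since compound 1 already holds the pentyl group at a value matching compound 2, no step beyond the scatter is expected in this assay, and the estimated step of a 1.0-fold lower number from compound 2 to compound 3 (0.02 log units; within the scatter) is taken as flat. Compound 3 is therefore expected to give about 7500 nM, between 3500 nM and 16000 nM.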

Compound 3, half-maximal inhibitory concentration: 6450 nM
Compound 3: middle estimate off by 1.2-fold (0.07 log units), on the high side, within the range that was stated.
By their numbers in this assay, from the lowest: compounds 3, 2 and 1 (each within the scatter of the next).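

With the 4-fluorophenyl group held in place, pentyl in place of isopropyl on the amide-type nitrogen can now be read on its own: in this assay it gives a 1.2-fold lower number from compound 2 to compound 3 (0.08 log units; within the scatter) and so does not separate the two chains. With the pentyl group held in place, 4-fluorophenyl in place of 2-methylphenyl on the nitrogen on an aromatic ring gives a 1.2-fold lower number from compound 1 to compound 3 (0.09 log units; within the scatter) and likewise stays within the scatter. Nothing available bears on why either step is so small. The compounds shown leave open whether a cyclohexyl group or a chain ending in a carboxylic acid or an amine on the amide-type nitrogen would move the number beyond the scatter.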